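Swapping dimethylamino for piperidin-1-yl on compound 1

This account rests on a few compounds, and the source may have more. Where it says the series, first, only, none or still open, it means among the compounds named here.

Measured in an ADME assay on microsomes from liver (Mus musculus) for metabolic stability, read by HPLC, with a stated time of 4 h; on this read-out higher numbers stand for a longer-lived compound and lower numbers for a shorter-lived compound:
- compound 1 `CN(C)c1ccc2cc(-c3cc(Cl)cc(Cl)c3)c(N)nc2c1`: 0.17 h
- compound 2 `CN(C)c1ccc2cc(-c3nc4cc(C(C)(C)C)ccc4o3)c(N)nc2c1`: 1.3 h

Within the data shown here, only two compounds have been measured so far. In this assay compound 1 stands at the bottom with 0.17 h, and compound 2, at 1.3 h, lies above it by more than the usual scatter.

Compound 3 `Nc1nc2cc(N3CCCCC3)ccc2cc1-c1cc(Cl)cc(Cl)c1` has not yet been measured. It keeps the core of compound 1 and carries piperidin-1-yl in place of dimethylamino on an aromatic carbon. Among the measured compounds shown here, no measured pair differs at this place, so the expectation rests on compound 1 alone and no direction can be argued with confidence. The expected change, a 1.1-fold lower number from compound 1 to compound 3 (0.03 log units; within the scatter), is none beyond the scatter. For compound 3 the expected half-life is 0.16 h, with an estimated range of 0.07 h to 0.4 h.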

Compound 3, half-life: 0.1 h
The estimate for compound 3 lay 1.6-fold (0.20 log units) above the measured number, and the stated range covers the measured number.
By their numbers in this assay, from the lowest: compounds 3 and 1 (each within the scatter of the next); then compound 2.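

In this assay, the first step read at this position, piperidin-1-yl in place of dimethylamino on an aromatic carbon, gives a 1.7-fold lower number from compound 1 to compound 3 (0.23 log units; within the scatter). Within this pair, then, going from the open dimethylamino to a six-membered non-aromatic ring does not separate the two half-lives, and the read-out cannot tell these two groups apart on the core of compound 1. Nothing at hand accounts for this result or says what happens to either group during the incubation.

From the compounds shown here alone, it remains open whether a different group at this place, such as morpholin-4-yl or a primary amine, would move the half-life beyond the scatter. Going by these compounds, it is also open whether piperidin-1-yl in place of dimethylamino would read the same way on compound 2.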